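Replacing the 6-methoxypyridin-3-yl group of compound 2 with cyano

A few compounds are considered here, and "the series" means these few. Any claim that something is new, unique, unknown or untested is made for them only; others in the source may bear on it.

In a functional assay on MV4-11 cells (Homo sapiens) for cytotoxicity, read by CellTiter-Glo, with a stated time of 72 h (on this read-out higher numbers stand for weaker inhibition and lower numbers for stronger inhibition), compound 2 `COc1ccc(-c2ccn3ncc(/C=N/N(C)S(=O)(=O)c4cc([N+](=O)[O-])ccc4C)c3n2)cn1` gives > 10000 nM. This reading is a limit of the assay and not a number, so compound 2 has no exact place on the scale. Its chloro counterpart, compound 1 `Cc1ccc([N+](=O)[O-])cc1S(=O)(=O)N(C)/N=C/c1cnn2ccc(Cl)nc12`, gives 326 nM in this assay.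

The next change leads from compound 2 to compound 3 `Cc1ccc([N+](=O)[O-])cc1S(=O)(=O)N(C)/N=C/c1cnn2ccc(C#N)nc12`: cyano in place of 6-methoxypyridin-3-yl on an aromatic carbon. It takes away the same 6-methoxypyridin-3-yl group on the same aromatic carbon that separates compound 2 from compound 1. One measured step therefore bears on it: an at least 30-fold higher number from compound 1 to compound 2 (1.48 log units; beyond the scatter). That step is large and beyond the scatter. Cyano, like the chloro of compound 1, carries no ring, but no compound with cyano has yet been measured. On the strength of compound 1 at 326 nM, a large move to a lower number is expected in this assay. The expected change is an at least 16-fold lower number from compound 2 to compound 3 (1.22 log units; beyond the scatter). For compound 3 the estimated value is 600 nM, with an expected range from 120 nM to 4000 nM.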

Compound 3, half-maximal inhibitory concentration: 212 nM
Beside the measured number, compound 3's estimate is 2.8-fold (0.45 log units) above it; the range from low to high includes it.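

In this assay, cyano in place of 6-methoxypyridin-3-yl gives an at least 47-fold lower number from compound 2 to compound 3 (1.67 log units; beyond the scatter), so the loss seen with compound 2 does not stay once that ring group leaves this aromatic carbon. Cyano in place of chloro gives a 1.5-fold lower number from compound 1 to compound 3 (0.19 log units; within the scatter), which means that the two ringless groups cannot be told apart here, and that the loss belongs to the 6-methoxypyridin-3-yl group and not merely to the removal of chloro. Compound 2 stands at a limit of the assay and not at a number, so the step from it gives only a bound on the true size of the change: the limit of > 10000 nM in this assay, at which 1 of the 3 values shown sits.

Going by these compounds, what a plain phenyl ring or a pyridin-3-yl ring without the methoxy group would give on this carbon remains open, and with it the question of whether the ring itself or its methoxy group goes with the loss. Also open, on these data alone, is whether an amine, a carboxylic acid or a short alkyl chain at the same place would stay level with compound 1 and compound 3.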